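The compounds below may be only part of what the source reports. "The series", "measured", "known", "first", "only" and "open" are said of these compounds alone.

Of the compounds shown here, three sharing one core have been measured in a functional assay on SK-BR-3 cells (Homo sapiens) for antiproliferative activity; on this read-out lower numbers stand for stronger inhibition and higher numbers for weaker inhibition. There, compound 1 (`CCCNCCCOc1ccc2cc(NC(=O)c3ccc(O)c(CC=C(C)C)c3)c(=O)oc2c1C`) gives 990 nM, compound 2 (`CC(C)=CCc1cc(C(=O)Nc2cc3ccc(OCCCNC(C)C)c(C)c3oc2=O)ccc1O`) gives 750 nM and compound 3 (`CC(C)=CCc1cc(C(=O)Nc2cc3ccc(OCCCNCCO)c(C)c3oc2=O)ccc1O`) gives 610 nM. Compound 3 therefore stands within the scatter of both other compounds, and the three values cannot be ranked.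

The next compound, compound 4 (`CC(C)=CCc1cc(C(=O)Nc2cc3ccc(OCCCNC(C)(C)c4ccccc4)c(C)c3oc2=O)ccc1O`), keeps the core of compound 3 but carries 1-methyl-1-phenylethyl in place of 2-hydroxyethyl on an amine nitrogen.

The measured steps that bear on this change all alter the same substituent on that nitrogen. They are a 1.3-fold lower number from compound 1 to compound 2 (0.12 log units; within the scatter), a 1.6-fold lower number from compound 1 to compound 3 (0.21 log units; within the scatter) and a 1.2-fold lower number from compound 2 to compound 3 (0.09 log units; within the scatter). Each of them lies within the scatter, so this assay has so far shown no response to changes at this group. Those steps cover only open-chain groups, however, and none of them places an aromatic ring there, so they offer limited guidance for compound 4. No step beyond the scatter is expected, in either direction, though the uncertainty is wide.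

The expected change is a 1.0-fold lower number from compound 3 to compound 4 (0.01 log units; within the scatter). For compound 4 the estimated value is 600 nM, with an expected range from 200 nM to 1800 nM.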

Compound 4, half-maximal inhibitory concentration: 960 nM
Compound 4: the middle estimate sits 1.6-fold (0.20 log units) below what was measured; the range from low to high includes it.
By their numbers in this assay, from the lowest: compounds 3, 2, 4 and 1 (each within the scatter of the next).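

Placed on the amine nitrogen in this assay, the 1-methyl-1-phenylethyl group brings a six-membered aromatic ring of carbon only to a place that had so far held open-chain groups, yet the number moves only by a 1.6-fold higher number from compound 3 to compound 4 (0.20 log units; within the scatter) and by a 1.3-fold higher number from compound 2 to compound 4 (0.11 log units; within the scatter) and stands at a 1.0-fold lower number from compound 1 to compound 4 (0.01 log units; within the scatter). The insensitivity seen among the open-chain groups therefore extends to a substituent of 9 heavy atoms with no hydrogen-bond donor or acceptor, so neither the ring nor the loss of the hydroxy group of 2-hydroxyethyl separates compound 4 from the other three compounds on this read-out. No supporting measurement is available that could account for this flat response.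

Going by these compounds, all four substituents leave the amine nitrogen with its hydrogen and carry no net charge, so it remains open whether an amide at that nitrogen, a ring containing that nitrogen, or a carboxylic acid on the substituent would give a step beyond the scatter. On these data alone, it also remains open whether a smaller aromatic substituent such as benzyl, or a longer chain, would behave as these four do.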